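Fluorophenyl replaces naphthalenyl on the shared core

A few compounds are considered here, and "the series" means these few. Any claim that something is new, unique, unknown or untested is made for them only; others in the source may bear on it.

Measured compounds in a functional assay on SR cells (Homo sapiens) for inhibition, read by sulforhodamine B assay, with a stated time of 48 h, tested at 10 uM; a lower number here means less inhibition, a higher number more inhibition at the concentration tested (going by the name of the read-out):
Compound 1 `c1ccc(-c2cn3ccnc3c(-c3ccc4ncn(C5CCCCC5)c4c3)n2)cc1` gives 59.8%
Compound 2 `O=Cc1ccc(-c2cn3ccnc3c(-c3ccc4ncn(C5CCCCC5)c4c3)n2)cc1` gives 47.5%
Compound 3 `c1ccc2c(-c3cn4ccnc4c(-c4ccc5ncn(C6CCCCC6)c5c4)n3)cccc2c1` gives 6.92%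

Compound 3 stands lowest of the three in this assay, beyond the scatter from both others. Compound 4 `Fc1ccc(-c2cn3ccnc3c(-c3ccc4ncn(C5CCCCC5)c4c3)n2)cc1` differs from compound 3 in one place: 4-fluorophenyl in place of naphthalen-1-yl on an aromatic carbon. The step that bears most on this change is a number 52.9 percentage points lower from compound 1 to compound 3 (beyond the scatter), which compound 4 largely reverses, since 4-fluorophenyl is closer to phenyl than to naphthalen-1-yl. The step of a number 12.3 percentage points lower from compound 1 to compound 2 (beyond the scatter) shows that a small group on the phenyl costs only modestly. The author therefore expects a large rise, a number 48.1 percentage points higher from compound 3 to compound 4 (beyond the scatter). Compound 4 is estimated at 55%, with a range from 35% to 72%.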

Compound 4, a percentage reported as inhibition, at one concentration (the size of the read-out at that concentration, not a potency): 20.4%
Compound 4: the middle estimate sits 34.6 percentage points above what was measured; measured number outside the range, below it.
By their numbers in this assay, from the lowest: compound 3; then compound 4; then compound 2; then compound 1.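

Fluoro on the phenyl proves far from neutral in this assay, with a number 39.4 percentage points lower from compound 1 to compound 4 (beyond the scatter) and a further fall of a number 27.1 percentage points lower from compound 2 to compound 4 (beyond the scatter) when it replaces formyl. Replacing naphthalen-1-yl with 4-fluorophenyl gives only a number 13.5 percentage points higher from compound 3 to compound 4 (beyond the scatter) and leaves compound 4 much nearer compound 3 than compound 1. Among these compounds, the group at this position therefore matters in a way that the similarity of 4-fluorophenyl to phenyl does not capture.

Nothing available explains why fluoro stands lower than formyl here. Going by these compounds, whether an amine or a carboxylic acid on the phenyl would stand nearer compound 1 or compound 4 remains open.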